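The source may report more compounds than this note shows. Statements on the series, on what has been measured and on what is new or still open speak of the compounds shown alone.

a functional assay on A549 cells (Homo sapiens) for inhibition, read by MTT assay, with a stated time of 24 h (on this read-out higher numbers stand for weaker inhibition and lower numbers for stronger inhibition), was run on three compounds built on one shared core. Compound 1 `C/C=C(\C)C(=O)O[C@H]1[C@]2(C)C[C@@H]3O[C@@]1(O)C=C1C4=CC(=O)O[C@@H](c5ccoc5)[C@]4(C)CC[C@@H]1[C@]3(C)[C@@H]2[C@@H](O)C(=O)OC` gives 8100 nM. Compound 2 `CCOC(=O)[C@H](O)[C@@H]1[C@@]2(C)C[C@@H]3O[C@@](O)(C=C4C5=CC(=O)O[C@@H](c6ccoc6)[C@]5(C)CC[C@@H]4[C@@]31C)[C@H]2O` gives 16300 nM, and compound 3 `COC(=O)[C@H](O)[C@@H]1[C@@]2(C)C[C@@H]3O[C@@](O)(C=C4C5=CC(=O)O[C@@H](c6ccoc6)[C@]5(C)CC[C@@H]4[C@@]31C)[C@H]2O` gives 9600 nM. Within the data shown here, compound 1 shows the lowest of the three numbers, but all three sit close together: the step of a 1.2-fold higher number from compound 1 to compound 3 (0.07 log units; within the scatter) stays within the scatter, and the values of compound 1 and compound 2 also lie within the scatter of each other, so no compound can be singled out as stronger or weaker than the rest.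

Compound 4 `C/C=C(\C)C(=O)O[C@H]1[C@]2(C)C[C@@H]3O[C@@]1(O)C=C1C4=CC(=O)O[C@@H](c5ccoc5)[C@]4(C)CC[C@@H]1[C@]3(C)[C@@H]2C(=O)C(=O)OC` has not yet been measured in this assay. It differs from compound 1 in a single place: (methoxycarbonyl)carbonyl in place of hydroxy(methoxycarbonyl)methyl on a saturated ring carbon. Neither measured step touches this group. The step of a 1.2-fold higher number from compound 1 to compound 3 (0.07 log units; within the scatter) removed a group from an oxygen elsewhere on the core, and the step of a 1.7-fold lower number from compound 2 to compound 3 (0.23 log units; within the scatter) shortened the ester chain; both remained within the scatter, showing that two changes at other places on this core left the read-out essentially unmoved. Among the measured compounds shown here, no measured step therefore speaks directly to the present change, and on the evidence at hand a step of no more than the scatter, in either direction, is expected in this assay.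

Compound 4 is accordingly estimated at 9000 nM, with a range from 3500 nM to 23000 nM. The expected step is a 1.1-fold higher number from compound 1 to compound 4 (0.05 log units; within the scatter).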

Compound 4, half-maximal inhibitory concentration: 44400 nM
Compound 4: the middle estimate sits 4.9-fold (0.69 log units) below what was measured; measured number above the stated range.
By their numbers in this assay, from the lowest: compounds 1, 3 and 2 (each within the scatter of the next); then compound 4.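

Two earlier steps changed other places on the shared core and stayed within the scatter, but this position does respond in this assay: placing (methoxycarbonyl)carbonyl where hydroxy(methoxycarbonyl)methyl stood, on a saturated ring carbon, gives a 5.5-fold higher number from compound 1 to compound 4 (0.74 log units; beyond the scatter), which here means weaker inhibition. The swap keeps the number and kind of heavy atoms in the group, yet the leaving group carries a hydrogen-bond donor and a defined stereocentre, and the entering group carries neither, so even a small edit at this spot can shift the read-out beyond the scatter. Nothing measured here says what lies behind this shift.

The compounds shown leave open whether the same swap would move the read-out similarly on the core of compound 3, where the (1-methylprop-1-en-1-yl)carbonyl group is replaced by hydrogen. They also leave open how the read-out would respond to an amine in place of the hydroxy group on this side chain, or to a carboxylic acid in place of its methyl ester.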